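The source may hold more compounds than are shown below. What is called first, only, known or untested is meant among the compounds shown, and "the series" means these compounds.

Measured in a functional assay on HeLa cells (Homo sapiens) for antiproliferative activity, read by cell counting, with a stated time of 72 h; on this read-out lower numbers stand for stronger inhibition and higher numbers for weaker inhibition:

- compound 1 `C#C[C@@]1(O)[C@@H](CO)O[C@@H](n2cnc3c(-c4ccc(Cl)cc4)ncnc32)[C@@H]1O`: 170000 nM
- compound 2 `C#C[C@@]1(O)[C@@H](CO)O[C@@H](n2cc(I)c3c(N)ncnc32)[C@@H]1O`: 180 nM
- compound 3 `C#C[C@@]1(O)[C@@H](CO)O[C@@H](n2cc(Cl)c3c(Cl)ccnc32)[C@@H]1O`: 6300 nM

These three compounds spread widely in this assay. Compound 3, at 6300 nM, holds the middle place, with the second highest number of the three. Its number lies beyond the scatter from both of the others, being lower than that of compound 1 and higher than that of compound 2.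

The next compound, compound 4 `C#C[C@@]1(O)[C@@H](CO)O[C@@H](n2ccc3c(Cl)ccnc32)[C@@H]1O`, has not yet been measured. It departs from compound 3 at a single place (hydrogen in place of chloro on an aromatic carbon), with hydrogen in place of chloro on an aromatic carbon. That carbon belongs to a five-membered aromatic ring with 1 nitrogen, part of a fused or bridged system of two rings, and lies two ring bonds from the ring nitrogen.

For the measured compounds named here, no two measured compounds differ in one place only, so the data hold no direct precedent for this change. The expectation is therefore tentative: a moderate move towards weaker inhibition in this assay, probably beyond the scatter, though no change at all cannot be ruled out. The estimated move is a 3.2-fold higher number from compound 3 to compound 4 (0.50 log units; beyond the scatter). For compound 4 the expected value is 20000 nM, within an estimated range of 3500 nM to 100000 nM.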

Compound 4, half-maximal inhibitory concentration: 135000 nM
The estimate for compound 4 lay 6.8-fold (0.83 log units) below the measured number; the measured number lies above the stated range.
By their numbers in this assay, from the lowest: compound 2; then compound 3; then compounds 4 and 1 (each within the scatter of the next).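

Taking chloro away and leaving hydrogen on this aromatic carbon of the five-membered aromatic ring gives, in this assay, a 21-fold higher number from compound 3 to compound 4 (1.33 log units; beyond the scatter), the first step in this set that changes one place only. It shows that this position, two ring bonds from the ring nitrogen and two ring bonds from the ring atom that bears a large group, is far from indifferent to what it carries: with everything else in the molecule unchanged, the loss of a single chlorine atom is enough to leave compound 4 at 135000 nM. No measured evidence at hand bears on why the step is this large.

On these data alone, what bromo, methyl or a nitrile on this same carbon would give remains open, so it cannot yet be said whether chloro itself matters or whether other groups in place of hydrogen would serve as well. Also open, as far as these compounds go, is whether the same change would have a step of similar size on the core of compound 2, which differs from compound 3 in more than one place.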